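Removing a Methyl from a Triazole-Bearing Cytotoxicity Probe

This account rests on a few compounds, and the source may have more. Where it says the series, first, only, none or still open, it means among the compounds named here.

Measured so far:
compound 1 `Cc1ccc(-c2cn(CCC3(O)NC(=O)C(OCc4ccccc4)=C3OCc3ccccc3)nn2)cc1`: 45000 nM
compound 2 `CCCc1cn(CCC2(O)C(OCc3ccccc3)=C(OCc3ccccc3)C(=O)N2CCC)nn1`: 90000 nM

In an ADME assay on HEK293 cells (Homo sapiens) for cytotoxicity, read by MTT assay, with a stated time of 24 h (on this read-out higher numbers stand for weaker inhibition and lower numbers for stronger inhibition), compound 1 gives 45000 nM. In this assay compound 2 gives 90000 nM, and the two numbers lie within the usual scatter of each other, so neither compound can be placed ahead of the other. Compound 3 `O=C1NC(O)(CCn2cc(-c3ccccc3)nn2)C(OCc2ccccc2)=C1OCc1ccccc1` has not been tested. It differs from compound 1 as follows: hydrogen in place of methyl on an aromatic carbon. Among the measured compounds shown here, no measured pair shows what this change does here, so in this assay a small step is expected, with no direction beyond the scatter. Compound 3 is therefore estimated at 45000 nM, within a range from 20000 nM to 100000 nM. The expected step is no change at the digits printed from compound 1 to compound 3 (within the scatter).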

Compound 3, half-maximal inhibitory concentration: > 100000 nM
Compound 3: only a limit was reported; the forecaster's own chance of this, stated with the estimate: 20%; at least 2.2-fold (0.34 log units) between middle value and limit.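

Compound 3 gives > 100000 nM in this assay, which is a limit and not a number. Replacing the methyl of the 4-methylphenyl group with hydrogen gives an at least 2.2-fold higher number from compound 1 to compound 3 (0.34 log units; beyond the scatter), so this position matters in this cytotoxicity read-out, and of this pair, the methyl-bearing compound inhibits more strongly. The true size of the step cannot be read, because compound 3 gives only a limit: the limit of > 100000 nM in this assay, at which 1 of the 3 values shown sits.

Going by these compounds, whether only a methyl does this remains open. A chlorine, a methoxy group or a longer chain at the same place could show whether other groups behave alike.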